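This account rests on a few compounds, and the source may have more. Where it says the series, first, only, none or still open, it means among the compounds named here.

Compound 1 `CCOC(=O)[C@H](CCC(=O)O)NC(=O)c1ccc(Sc2nc3cc(N)cc(N)c3nc2-c2ccccc2)cc1`: 17400 nM
Compound 2 `Nc1cc(N)c2nc(-c3ccccc3)c(Oc3ccc(F)cc3)nc2c1`: 23400 nM
Compound 3 `CCOC(=O)[C@H](CCC(=O)O)NC(=O)c1ccc(Oc2nc3cc(N)cc(N)c3nc2-c2ccccc2)cc1`: 26900 nM

The three compounds were all tested in a functional assay on UACC-257 cells (Homo sapiens) for inhibition, read by sulforhodamine B assay, with a stated time of 48 h; on this read-out higher numbers stand for weaker inhibition of growth and lower numbers for stronger inhibition of growth. Compound 2 gives 23400 nM, which stands between the other two numbers: compound 3 gives 26900 nM, and compound 1 gives 17400 nM. Both gaps from compound 2 lie within the usual scatter of this assay, so the three measured compounds cannot be told apart in potency on these numbers; all of them inhibit growth only weakly.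

Compound 4 `Nc1cc(N)c2nc(-c3ccccc3)c(NCc3ccc(F)cc3)nc2c1` has not yet been measured. It differs from compound 2 in one place: (4-fluorobenzyl)amino in place of 4-fluorophenoxy on an aromatic carbon. Within the data shown here, nothing among the measured compounds shows what this change does, as no two of them differ in exactly this way. Since every measured compound sits at a similar weak level, the account expects no step beyond the scatter for this change, in either direction. The expected step is a 1.1-fold lower number from compound 2 to compound 4 (0.05 log units; within the scatter). The estimate for compound 4 is therefore 21000 nM, with a range from 6000 nM to 70000 nM.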

Compound 4, concentration for 50% growth inhibition: 2040 nM
For compound 4 the middle estimate is 10-fold (1.01 log units) above the measured one; the measured number lies below the stated range.
By their numbers in this assay, from the lowest: compound 4; then compounds 1, 2 and 3 (each within the scatter of the next).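

In this assay, placing (4-fluorobenzyl)amino in place of 4-fluorophenoxy on the aromatic carbon next to the ring nitrogen gives an 11-fold lower number from compound 2 to compound 4 (1.06 log units; beyond the scatter) and so sets compound 4 clearly apart from compounds 1, 2 and 3. Among these compounds, this shows that growth inhibition responds strongly to the group at this position, which the close numbers of the earlier compounds had not revealed. The entering group differs from the leaving one in both its nitrogen and its extra carbon, and nothing shown here accounts for the stronger inhibition.

From the compounds shown here alone, what a benzyloxy or a phenylamino group would do at this position stays open, so the contributions of the nitrogen and the extra carbon remain unseparated. Going by these compounds, whether the fluorine matters also stays open, as would be tested by a plain benzylamino group.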